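Capping the Phenolic Hydroxyl: From Compound 2 to Compound 4

A few compounds are considered here, and "the series" means these few. Any claim that something is new, unique, unknown or untested is made for them only; others in the source may bear on it.

Three measured compounds share one core and differ only on one aromatic ring. Compound 1 `O=C(/C=C/c1ccc2c(c1)B(O)OC2)c1ccccc1` gives 2300 nM in a functional assay on MDA-MB-231 cells (Homo sapiens) for cytotoxicity, read by MTT assay, with a stated time of 48 h; a higher number here means a weaker inhibitor, a lower number a stronger inhibitor. Compound 2 `O=C(/C=C/c1ccc2c(c1)B(O)OC2)c1ccccc1O` gives 16900 nM in this assay, and compound 3 `O=C(/C=C/c1ccc2c(c1)B(O)OC2)c1cccc(O)c1` gives 2700 nM in this assay. Compound 2 is the weakest inhibitor of the three: a 7.3-fold higher number from compound 1 to compound 2 (0.87 log units; beyond the scatter), and a 6.3-fold lower number from compound 2 to compound 3 (0.80 log units; beyond the scatter). Compound 4 `COCOc1ccccc1C(=O)/C=C/c1ccc2c(c1)B(O)OC2` differs from compound 2 by methoxymethyl in place of hydrogen on an oxygen on an aromatic ring. Among the compounds with values here, no measured step covers this exact change; the steps that bear on it show only that the hydroxy of compound 2 carried the loss, since a 1.2-fold higher number from compound 1 to compound 3 (0.07 log units; within the scatter) while placing it as in compound 2 cost far more. Covering that hydroxy is therefore expected to recover part of that loss, a modest step of a 2.8-fold lower number from compound 2 to compound 4 (0.45 log units; beyond the scatter). For compound 4 the expected value is 6000 nM, with a range from 2000 nM to 18000 nM.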

Compound 4, half-maximal inhibitory concentration: 10200 nM
Compound 4: the middle estimate sits 1.7-fold (0.23 log units) below what was measured; measured number inside the range.
By their numbers in this assay, from the lowest: compounds 1 and 3 (each within the scatter of the next); then compounds 4 and 2 (each within the scatter of the next).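

Covering the hydroxy with methoxymethyl leaves the number in this assay without a clear change (a 1.7-fold lower number from compound 2 to compound 4 (0.22 log units; within the scatter)). The covered compound still stands apart from the compound with plain hydrogen on that ring (a 4.4-fold higher number from compound 1 to compound 4 (0.65 log units; beyond the scatter)), so here removing the free hydroxy does not by itself restore the number of compound 1. Nothing available gives a reason for this result.

Open, on these data alone, is whether a plain methyl on this oxygen, or a longer chain ending in an amine, would give a number closer to that of compound 1. Also open, as far as these compounds go, is how methoxymethyl would behave on the hydroxy of compound 3.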